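The source may hold more compounds than are shown below. What is called first, only, known or untested is meant among the compounds shown, and "the series" means these compounds.

Compounds measured so far:
- compound 1 `COc1ccccc1-c1nnc(-c2ccc(C(=O)N/N=C/c3ccncc3)cc2)o1`: 173000 nM
- compound 2 `COc1ccccc1-c1nnc(-c2ccc(C(=O)N/N=C/c3c(O)cc(O)cc3O)cc2)o1`: 12400 nM
- compound 3 `COc1ccccc1-c1nnc(-c2ccc(C(=O)N/N=C/c3ccc(O)cc3)cc2)o1`: 261000 nM

In an ADME assay on THP-1 cells (Homo sapiens) for cytotoxicity (on this read-out higher numbers stand for weaker inhibition and lower numbers for stronger inhibition), compound 2 gives the lowest of the three numbers, with a 14-fold lower number from compound 1 to compound 2 (1.14 log units; beyond the scatter) and a 21-fold higher number from compound 2 to compound 3 (1.32 log units; beyond the scatter) both beyond the scatter. Compound 4 `COc1ccccc1-c1nnc(-c2ccc(C(=O)N/N=C/c3ccccc3F)cc2)o1` differs from compound 2 in one place: 2-fluorophenyl in place of 2,4,6-trihydroxyphenyl on a carbon with a double bond to nitrogen. The bearing steps are a 21-fold higher number from compound 2 to compound 3 (1.32 log units; beyond the scatter) and a 14-fold lower number from compound 1 to compound 2 (1.14 log units; beyond the scatter); in each the 2,4,6-trihydroxyphenyl compound sits well below its partner. Compound 4 also lacks the 2,4,6-trihydroxyphenyl, so a large step to a higher number is expected in this assay, roughly a 15-fold higher number from compound 2 to compound 4 (1.16 log units; beyond the scatter), placing compound 4 near compounds 1 and 3. Compound 4 is estimated at 180000 nM, with a range from 60000 nM to 400000 nM.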

Compound 4, half-maximal inhibitory concentration: 313000 nM
The estimate for compound 4 lay 1.7-fold (0.24 log units) below the measured number; the range from low to high includes it.
By their numbers in this assay, from the lowest: compound 2; then compounds 1, 3 and 4 (each within the scatter of the next).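

In this assay the 2-fluorophenyl group falls on the same side of the large step as pyridin-4-yl and 4-hydroxyphenyl (a 25-fold higher number from compound 2 to compound 4 (1.40 log units; beyond the scatter)), while the other two steps stay within the scatter (a 1.2-fold higher number from compound 3 to compound 4 (0.08 log units; within the scatter); a 1.8-fold higher number from compound 1 to compound 4 (0.26 log units; within the scatter)). At this carbon, a ring with no hydrogen-bond donors thus matches the compounds carrying pyridin-4-yl and 4-hydroxyphenyl, leaving only the 2,4,6-trihydroxyphenyl group apart. No supporting evidence bears on this result.

Still open, on these data alone, is whether the low number of compound 2 requires all the hydroxyl groups together. As far as these compounds go, it is also open whether methoxy groups or an amine on that ring would retain it.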